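The source may hold more compounds than are shown below. What is called first, only, known or untested is meant among the compounds shown, and "the series" means these compounds.

Measured so far in an assay on CHO-K1 cells for displacement of a labelled ligand from prostaglandin E2 receptor EP1 subtype (Homo sapiens); a higher number here means a weaker inhibitor, a lower number a stronger inhibitor:
compound 1 `Cc1cc(C(=O)Nc2cccc(F)c2)nn1Cc1cc(Cl)ccc1OCc1ccccc1`: 200 nM
compound 2 `Cc1cc(C(=O)NCc2ccccc2)nn1Cc1cc(Cl)ccc1OCc1ccccc1`: 39.8 nM

Going by the values given here, compound 2 holds the lower of the two numbers; its nearest neighbour is compound 1, and the single step recorded so far, a 5.0-fold lower number from compound 1 to compound 2 (0.70 log units; beyond the scatter), separates them.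

Compound 3 `Cc1cc(C(=O)NCc2ccncc2)nn1Cc1cc(Cl)ccc1OCc1ccccc1` differs from compound 2 in one place: pyridin-4-yl in place of phenyl on a saturated chain carbon bound to an amide-type nitrogen. Among the compounds with values here, no measured step covers an exchange of this kind. Within the data shown here, the only step available, a 5.0-fold lower number from compound 1 to compound 2 (0.70 log units; beyond the scatter), replaces the whole aryl group on the amide nitrogen and leaves the phenyl of the benzyl untouched, so it does not bear directly on the present change. Without a precedent, no step beyond the scatter is expected in this assay in either direction, and the range is kept wide. For compound 3 the expected step is a 1.5-fold higher number from compound 2 to compound 3 (0.18 log units; within the scatter). Compound 3 is therefore estimated at 60 nM in this assay, within a range from 20 nM to 200 nM.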

Compound 3, half-maximal inhibitory concentration: 79.4 nM
Estimate against measurement, compound 3: 1.3-fold (0.12 log units) below; low and high end bracket the measured number.
By their numbers in this assay, from the lowest: compounds 2 and 3 (each within the scatter of the next); then compound 1.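

In this assay, the aromatic ring on the saturated chain carbon bound to an amide-type nitrogen now has its first exchange: pyridin-4-yl in place of phenyl gives a 2.0-fold higher number from compound 2 to compound 3 (0.30 log units; within the scatter), so a ring nitrogen with one hydrogen-bond acceptor is accepted here without a step that can be resolved. The (pyridin-4-yl)methyl group also remains separated from 3-fluorophenyl on the amide-type nitrogen, with a 2.5-fold lower number from compound 1 to compound 3 (0.40 log units; beyond the scatter), so the earlier gain seen with benzyl is not confined to an all-carbon ring. No evidence accompanies these results that would explain either step.

Open, going by these compounds, is whether pyridin-3-yl or pyridin-2-yl reads like pyridin-4-yl on the same chain carbon. Also open, on these data alone, is how a longer chain, such as 2-phenylethyl, or an amine or carboxylic acid on the ring would read.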